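Amide Substituent Variation on a Shared Kinase Inhibitor Core

The compounds below may be only part of what the source reports. "The series", "measured", "known", "first", "only" and "open" are said of these compounds alone.

Two measured compounds share one core and differ only in the amide substituent. Compound 1 `CC(=O)N1CC(CNC(=O)c2ccncc2Nc2cc(-c3ccc4ccn(C)c4c3)c3nccnc3c2)C1` in an assay on lysate for inhibition of 6-phosphofructo-2-kinase/fructose-2,6-bisphosphatase 3 (Homo sapiens), with stated times of 0.5 min and 45 min (a lower number here means a stronger inhibitor, a higher number a weaker inhibitor), reaches only a limit, > 100000 nM. Compound 2 `CN1CCC(N(C)C(=O)c2ccncc2Nc2cc(-c3ccc4ccn(C)c4c3)c3nccnc3c2)C1` gives 39700 nM in this assay, and the step of an at least 2.5-fold lower number from compound 1 to compound 2 (0.40 log units; beyond the scatter) moves beyond the scatter. Compound 2 therefore holds the only number shown; the other value is the limit described by the limit of > 100000 nM in this assay, at which 1 of the 2 values shown sits.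

Compound 3 `CC(=O)N1CCC(NC(=O)c2ccncc2Nc2cc(-c3ccc4ccn(C)c4c3)c3nccnc3c2)C1` differs from compound 2 by (1-acetylpyrrolidin-3-yl)amino in place of methyl(1-methylpyrrolidin-3-yl)amino on a carbonyl carbon. This change brings back an acetyl group and an amide hydrogen, both of which compound 1 carries and compound 2 lacks, while the five-membered ring stays. Among the measured compounds shown here, the one measured step that bears on it, an at least 2.5-fold lower number from compound 1 to compound 2 (0.40 log units; beyond the scatter), ran toward stronger inhibition when the acetyl and the amide hydrogen departed; compound 3 partly reverses that change, so a step of at least modest size toward weaker inhibition is expected, with a real chance that only a limit is reported. Compound 3 is estimated at 80000 nM, within 25000 nM to 250000 nM, which means an expected step of a 2.0-fold higher number from compound 2 to compound 3 (0.30 log units; within the scatter).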

Compound 3, half-maximal inhibitory concentration: > 100000 nM
Compound 3 was reported as a limit; the forecaster's own chance of this, stated with the estimate: 45%; middle value at least 1.2-fold (0.09 log units) from the limit.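

In this assay compound 3 gives > 100000 nM, which is a limit of the assay and not a number. Replacing methyl(1-methylpyrrolidin-3-yl)amino with (1-acetylpyrrolidin-3-yl)amino on a carbonyl carbon gives an at least 2.5-fold higher number from compound 2 to compound 3 (0.40 log units; beyond the scatter), so the measurable value is lost when the acetyl group and the amide hydrogen return, even though the five-membered ring stays; the earlier step could not show this, since it also replaced the (1-acetylazetidin-3-yl)methyl group. The step from compound 1 to compound 3 cannot be read, and the two acetylated compounds can only be said to share the same ceiling: the limit of > 100000 nM in this assay, at which 2 of the 3 values shown sit.

The step changes two features at once, so the compounds shown do not tell whether the acetyl group on the ring or the hydrogen on the amide nitrogen accounts for it. On these data alone, it also remains open whether a primary amine, a piperidine ring or a carboxylic acid on this carbonyl carbon would give a clearly lower number than compound 2 does, or would also end at the limit.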